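Trimming the Ether Chain from Propoxy to Methoxy

This account rests on a few compounds, and the source may have more. Where it says the series, first, only, none or still open, it means among the compounds named here.

Three measured compounds share one core and differ only in the group attached through an oxygen on an aromatic ring. Compound 1 `O=C1CC(c2ccccc2OCc2cccc(F)c2)Oc2ccccc21` carries a 3-fluorophenyl on a saturated chain carbon bound to that oxygen, and in a functional assay on RAW264.7 cells (Mus musculus) for inhibition, read by immunoassay, with a stated time of 12 h, tested at 30 uM (a lower number here means less inhibition, a higher number more inhibition at the concentration tested (going by the name of the read-out)), compound 1 gives 93.3%. Compound 2 `CC(C)=CCOc1ccccc1C1CC(=O)c2ccccc2O1` carries a 2-methylprop-1-en-1-yl there, and compound 2 gives 41.8%. Compound 3 `CCCOc1ccccc1C1CC(=O)c2ccccc2O1` carries an ethyl, and compound 3 gives 45.7%.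

Compound 3 thus holds the second highest of the three numbers. Its nearest neighbour is compound 2, the gap being a number 3.9 percentage points higher from compound 2 to compound 3 (within the scatter). Its furthest is compound 1, the gap being a number 47.6 percentage points lower from compound 1 to compound 3 (beyond the scatter), and likewise a number 51.5 percentage points lower from compound 1 to compound 2 (beyond the scatter).

Compound 4 `COc1ccccc1C1CC(=O)c2ccccc2O1` is not yet measured. It differs from compound 3 as follows: hydrogen in place of ethyl on a saturated chain carbon bound to an oxygen on an aromatic ring. Read one bond further out, propoxy becomes methoxy.

Going by the values given here, of the measured steps, only the one between two non-aromatic chains bears directly on this change, and it stayed within the scatter. The large drops appeared only when the 3-fluorophenyl was removed. No step beyond the scatter is therefore expected, a number 3.7 percentage points lower from compound 3 to compound 4 (within the scatter). The expected value for compound 4 is 42%, with a range from 25% to 60%.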

Compound 4, a percentage reported as inhibition, at one concentration (the size of the read-out at that concentration, not a potency): 37.3%
Compound 4: the middle estimate sits 4.7 percentage points above what was measured; low and high end bracket the measured number.
By their numbers in this assay, from the lowest: compounds 4, 2 and 3 (each within the scatter of the next); then compound 1.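

In this assay, putting hydrogen in place of ethyl, which turns propoxy into methoxy, gives a number 8.4 percentage points lower from compound 3 to compound 4 (within the scatter) and so leaves the read-out unchanged within the usual scatter of repeat measurements. Putting hydrogen in place of 2-methylprop-1-en-1-yl gives a number 4.5 percentage points lower from compound 2 to compound 4 (within the scatter) as well, so the methoxy, propoxy and 2-methylprop-1-en-1-yl compounds cannot be told apart in this assay. Putting hydrogen in place of 3-fluorophenyl gives a number 56 percentage points lower from compound 1 to compound 4 (beyond the scatter) and shows that the large gap separating compound 1 from the others also holds against the smallest group in the set. Nothing measured here says why the numbers fall as they do. The compounds shown leave open whether the large gap depends on the aromatic ring itself or on its fluorine, a question that a plain phenyl in place of 3-fluorophenyl would address. They also leave open whether a longer chain such as hexyl, or an amine at the end of the chain, would stay level with compound 3 or approach compound 1.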